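The source may report more compounds than this note shows. Statements on the series, on what has been measured and on what is new or still open speak of the compounds shown alone.

Measured compounds:
- compound 1 `CCCCCCCCCCCCn1nnc(C(NC(=O)c2c(C(C)C)cccc2C(C)C)c2ccccc2)n1`: 810 nM
- compound 2 `CCCCCCCCCCCCn1nnc(C(NC(=O)c2cccc([N+](=O)[O-])c2)c2ccccc2)n1`: 80 nM
- compound 3 `CCCCCCCCCCCCn1nnc(C(NC(=O)c2ccc(C(F)(F)F)cc2)c2ccccc2)n1`: 850 nM

The three compounds share one core and differ only in the aromatic group attached to the carbonyl carbon of the amide. In an assay on microsomes from liver for inhibition of sterol O-acyltransferase 1 (Rattus norvegicus) (a higher number here means a weaker inhibitor, a lower number a stronger inhibitor), compound 3 gives 850 nM, the highest of the three numbers. Compound 1 sits within the scatter of it (a 1.0-fold higher number from compound 1 to compound 3 (0.02 log units; within the scatter)), so the two cannot be told apart, while compound 2 stands clearly apart (an 11-fold higher number from compound 2 to compound 3 (1.03 log units; beyond the scatter)).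

Compound 4 `CCCCCCCCCCCCn1nnc(C(NC(=O)c2ccnc(SC)c2)c2ccccc2)n1` is not yet measured. It keeps the core of compound 3 and carries a group of 8 heavy atoms (6 carbon, 1 nitrogen, 1 sulfur; one six-membered aromatic ring with 1 hetero atom) in place of a group of 10 heavy atoms (7 carbon, 3 fluorine; one six-membered aromatic ring of carbon only), on a carbonyl carbon.

Within the data shown here, no measured step introduces the entering group, so only indirect guidance exists: swapping one aromatic group for another on this carbonyl carbon changed this assay by a large step in one case (a 10-fold lower number from compound 1 to compound 2 (1.01 log units; beyond the scatter)) and not at all in another (a 1.0-fold higher number from compound 1 to compound 3 (0.02 log units; within the scatter)). A change in either direction is therefore possible, and a wide range is warranted. For compound 4 the expected value in this assay is 500 nM, with a range from 120 nM to 2000 nM. This corresponds to an expected 1.7-fold lower number from compound 3 to compound 4 (0.23 log units; within the scatter).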

Compound 4, half-maximal inhibitory concentration: 80 nM
Compound 4: middle estimate off by 6.3-fold (0.80 log units), on the high side; the whole stated range lies above it.
By their numbers in this assay, from the lowest: compounds 2 and 4 (each within the scatter of the next); then compounds 1 and 3 (each within the scatter of the next).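

The entering group, a six-membered aromatic ring with 1 hetero atom, gives large steps in this assay against both 4-(trifluoromethyl)phenyl (an 11-fold lower number from compound 3 to compound 4 (1.03 log units; beyond the scatter)) and 2,6-diisopropylphenyl (a 10-fold lower number from compound 1 to compound 4 (1.01 log units; beyond the scatter)), showing that an aromatic ring containing a hetero atom is accepted on this carbonyl carbon. Against 3-nitrophenyl it gives no change at the digits printed from compound 2 to compound 4 (within the scatter), so a second, quite different group now matches the one earlier low value, and that value no longer rests on a single compound. No measurement shown explains what these two groups have in common.

The compounds shown do not separate the contribution of the ring nitrogen from that of the sulfur atom. From the compounds shown here alone, whether an oxygen in place of that sulfur, or an amine or a carboxylic acid on the ring, would keep this level also remains open.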